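The source may hold more compounds than are shown below. What is called first, only, known or untested is meant among the compounds shown, and "the series" means these compounds.

Working notes on the series.

Of the compounds shown here, three sharing one core have been measured in a functional assay on HEK293 cells for agonist activity at growth hormone secretagogue receptor type 1 (Homo sapiens), read by HTRF and inositol phosphate accumulation, with a stated time of 90 min, in the presence of a further agent that is not named here; on this read-out higher numbers stand for larger maximal responses and lower numbers for smaller maximal responses. Compound 1 `Cc1ccc2[nH]c(C(=O)N[C@H]3CN(S(=O)(=O)c4ccnnc4)C[C@@H]3C(=O)NCCN(C)C)cc2c1` gives 89%. Compound 2 `Cc1ccc2[nH]c(C(=O)N[C@H]3CN(S(=O)(=O)c4ccnc(C)c4)C[C@@H]3C(=O)NCCN(C)C)cc2c1` gives 91%. Compound 3 `Cc1ccc2[nH]c(C(=O)N[C@H]3CCN(S(=O)(=O)c4cccnc4)C[C@@H]3C(=O)NCCN(C)C)cc2c1` gives 93%. All three reach much the same maximal response; the number for compound 3 is the highest of the three, but its gaps to compound 2 and to compound 1 both lie within the scatter, so no order among them can be claimed.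

Among the compounds with values here, the only single-point step measured so far is a number 2 percentage points higher from compound 1 to compound 2 (within the scatter); it exchanges one aryl group for another on the sulfonyl sulfur and leaves the maximal response unchanged within the scatter.

Compound 4 `Cc1ccc2[nH]c(C(=O)N[C@H]3CCN(C(=O)c4cccnc4)C[C@@H]3C(=O)NCCN(C)C)cc2c1` is not yet measured. It differs from compound 3 as follows: (pyridin-3-yl)carbonyl in place of (pyridin-3-yl)sulfonyl on an amine nitrogen in a ring. Within the data shown here, no measured step addresses an exchange of a sulfonyl for a carbonyl linker on the ring amine nitrogen, so the step 1>2 bears only indirectly, showing that the ring amine substituent tolerates variation without loss of response.

On that basis compound 4 is expected to remain a near-full agonist, with a step of a number 6 percentage points lower from compound 3 to compound 4 (within the scatter) in this assay that stays within the scatter. The estimated value for compound 4 is 87%, in the range 70% to 100%.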

Compound 4, largest response reached (Emax), in percent of the reference or control that the assay uses: 91%
Compound 4: middle estimate off by 4 percentage points, on the low side, within the range that was stated.
By their numbers in this assay, from the lowest: compounds 1, 2, 4 and 3 (each within the scatter of the next).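

Within the data shown here, the step of a number 2 percentage points lower from compound 3 to compound 4 (within the scatter) is the first measured exchange of the linking group itself on the amine nitrogen in the ring; the earlier step changed only the aryl group on a sulfonyl sulfur. In this assay, the maximal response stays within the scatter when (pyridin-3-yl)carbonyl replaces (pyridin-3-yl)sulfonyl, so a sulfonyl link is not needed to keep that response in this pair. The pyridin-3-yl group is the same on both sides of the step, which isolates the finding to the link, but it rests on this one pair with the six-membered ring.

Nothing available explains why the response holds across this exchange. The compounds shown leave open whether a urea, a simple alkyl chain or an unsubstituted ring amine at this nitrogen would keep the response, and whether the same carbonyl exchange would hold on the core of compound 1.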